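From Isopropyl Urea to Triazolylmethyl Urea

This account rests on a few compounds, and the source may have more. Where it says the series, first, only, none or still open, it means among the compounds named here.

Of the compounds shown here, three built on one shared core have been measured in an assay on CHO cells for displacement of a labelled ligand from Substance-P receptor (Homo sapiens); a higher number here means a weaker inhibitor, a lower number a stronger inhibitor. Compound 1 `C[C@@H](O[C@@H]1CN(C(=O)[C@@H]2CCC(=O)N2C)C[C@H]1c1ccc(F)cc1)c1cc(C(F)(F)F)cc(C(F)(F)F)c1` gives 0.12 nM in this assay. Compound 2 `Cc1cnc(C(=O)N2C[C@@H](O[C@H](C)c3cc(C(F)(F)F)cc(C(F)(F)F)c3)[C@H](c3ccc(F)cc3)C2)cn1` gives 0.12 nM in this assay. Compound 3 `CC(C)NC(=O)N1C[C@@H](O[C@H](C)c2cc(C(F)(F)F)cc(C(F)(F)F)c2)[C@H](c2ccc(F)cc2)C1` gives 0.06 nM in this assay. The three numbers sit close together: no change at the digits printed from compound 1 to compound 2 (within the scatter), a 2.0-fold lower number from compound 1 to compound 3 (0.30 log units; within the scatter) and a 2.0-fold lower number from compound 2 to compound 3 (0.30 log units; within the scatter). Compound 3 thus carries the lowest of the three numbers, but its steps to compound 1 and compound 2 lie within the scatter, so it cannot be set apart from them.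

Compound 4 `C[C@@H](O[C@@H]1CN(C(=O)NCc2cn[nH]n2)C[C@H]1c1ccc(F)cc1)c1cc(C(F)(F)F)cc(C(F)(F)F)c1` has not yet been measured. It differs from compound 3 in one place: (2H-1,2,3-triazol-4-yl)methyl in place of isopropyl on an amide-type nitrogen. Within the data shown here, none of the measured steps touches the amide-type nitrogen; the two steps into compound 3 change what sits on the carbonyl carbon, and both stayed within the scatter. Among the measured compounds shown here, no measured step therefore gives a direction for this change. The expected step is a 1.7-fold higher number from compound 3 to compound 4 (0.22 log units; within the scatter), not beyond the scatter. Compound 4 is estimated at 0.1 nM in this assay, with a range from 0.03 nM to 0.4 nM.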

Compound 4, half-maximal inhibitory concentration: 0.58 nM
Compound 4: the middle estimate sits 5.8-fold (0.76 log units) below what was measured, outside the stated range (above it).
By their numbers in this assay, from the lowest: compounds 3, 1 and 2 (each within the scatter of the next); then compound 4.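

In this assay, among these compounds, the amide-type nitrogen proves sensitive to its substituent: (2H-1,2,3-triazol-4-yl)methyl in place of isopropyl gives a 9.7-fold higher number from compound 3 to compound 4 (0.99 log units; beyond the scatter) and so the first step beyond the scatter. The ((2H-1,2,3-triazol-4-yl)methyl)amino group also stands apart from the other two groups on the carbonyl carbon, with a 4.8-fold higher number from compound 2 to compound 4 (0.68 log units; beyond the scatter) and a 4.8-fold higher number from compound 1 to compound 4 (0.68 log units; beyond the scatter) in contrast to the earlier changes there, which all stayed within the scatter. No measurement at hand says what in the new group accounts for this.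

From the compounds shown here alone, it remains open whether a benzyl group or a longer chain such as butyl on this nitrogen would side with compound 3 or with compound 4. Also open, going by these compounds, is whether the ring or its hydrogen-bond donor carries the step, as the two arrive together here.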